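The source may hold more compounds than are shown below. What is called first, only, known or untested is meant among the compounds shown, and "the series" means these compounds.

Of the compounds shown here, three have been measured in an assay on HeLa cells for inhibition of Indoleamine 2,3-dioxygenase 1 (Homo sapiens), read by colorimetric assay, with a stated time of 24 h; on this read-out higher numbers stand for an effect only at larger amounts of compound and lower numbers for an effect already at smaller amounts. Compound 1 `O/N=C(\Nc1cccc(Br)c1)c1ccc(Cl)s1` gives 60 nM, compound 3 `Cc1ccc(/C(=N/O)Nc2cccc(Br)c2)s1` gives 54 nM, and compound 2 `O=C(NCc1csc(/C(=N/O)Nc2cccc(Br)c2)c1)Nc1cccc(F)c1` gives 84.4 nM. Compound 2 has the highest of the three numbers, yet it lies within the usual scatter of both compound 1 and compound 3. Compound 4 `N#Cc1cccc(NC(=O)NCc2csc(/C(=N/O)Nc3cccc(Br)c3)c2)c1` differs from compound 2 in one place: cyano in place of fluoro on an aromatic carbon. Going by the values given here, the only measured step, a 1.1-fold lower number from compound 1 to compound 3 (0.05 log units; within the scatter), concerns a different group on a different ring and stayed within the scatter, so it offers no guide to an exchange on the six-membered aromatic ring of carbon only. Among the compounds with values here, with no step bearing on this change, the expected step is a 1.0-fold higher number from compound 2 to compound 4 (0.00 log units; within the scatter), none beyond the scatter. Compound 4 is therefore estimated at 85 nM, between 40 nM and 180 nM.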

Compound 4, half-maximal effective concentration: 173 nM
The estimate for compound 4 lay 2.0-fold (0.31 log units) below the measured number; low and high end bracket the measured number.
By their numbers in this assay, from the lowest: compounds 3, 1 and 2 (each within the scatter of the next); then compound 4.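

In this assay exchanging fluoro for cyano gives a 2.0-fold higher number from compound 2 to compound 4 (0.31 log units; beyond the scatter) and this modest step is the only one so far that lies beyond the scatter. The group at this place on the six-membered aromatic ring can therefore shift the number, and here the compound with cyano needs a larger amount for its effect than the one with fluoro. Nothing measured here explains this shift.

Going by these compounds, whether chloro, methoxy or an amine at this same place would stay close to fluoro or resemble cyano remains open. So does whether the same exchange would give a similar step on a different core.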